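Swapping chloro for hydroxy on a shared anti-inflammatory scaffold

The source may report more compounds than this note shows. Statements on the series, on what has been measured and on what is new or still open speak of the compounds shown alone.

Measured compounds:
compound 1, `N#Cc1c(-c2ccc(Cl)cc2)nc(SCC(=O)Nn2c(COc3ccc(Cl)cc3Cl)nc3ccccc3c2=O)n(Cc2ccccc2)c1=O`, 77.2%
compound 2, `N#Cc1c(-c2ccc(O)cc2)nc(SCC(=O)Nn2c(COc3ccc(Cl)cc3Cl)nc3ccccc3c2=O)n(Cc2ccccc2)c1=O`, 61.4%
compound 3, `N#Cc1c(Cl)nc(SCC(=O)Nn2c(COc3ccc(Cl)cc3Cl)nc3ccccc3c2=O)nc1-c1ccc(Cl)cc1`, 68.4%

All three compounds were tested in a functional assay on the whole organism (strain albino) for inhibition, with Rattus norvegicus as the target, read by paw edema, with stated times of 1 h and 3 h, at a dose of 100 mg/kg by the oral route; on this read-out lower numbers stand for a weaker effect and higher numbers for a stronger effect at the one dose given. In this assay compound 1 gives 77.2%, compound 2 gives 61.4%, and compound 3 gives 68.4%. The values of compound 1 and compound 3 lie within the scatter of each other, as do those of compound 3 and compound 2, so no order between those pairs can be read from the data.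

Compound 1 and compound 2 differ in one place: hydroxy in place of chloro on an aromatic carbon. This change made a step of a number 15.8 percentage points lower from compound 1 to compound 2 (beyond the scatter), a modest loss that lies beyond the scatter.

Compound 3 carries a different core from compound 1; the difference between the two cores is not broken down here. Compound 4, `N#Cc1c(Cl)nc(SCC(=O)Nn2c(COc3ccc(Cl)cc3Cl)nc3ccccc3c2=O)nc1-c1ccc(O)cc1`, has not yet been measured. It stands to compound 3 as compound 2 stands to compound 1: hydroxy in place of chloro on an aromatic carbon. The place of the change is the same in both pairs, so this is the same change made on a second core.

If the change behaves on the core of compound 3 as it did on the core of compound 1, compound 4 is expected to fall below compound 3 by about the earlier step, because that step was a number 15.8 percentage points lower from compound 1 to compound 2 (beyond the scatter) and compound 3 starts from 68.4%. The step from compound 3 to compound 4 is therefore estimated at a number 15.4 percentage points lower from compound 3 to compound 4 (beyond the scatter). For the measured compounds named here, compound 4 is accordingly expected to give about 53% in this assay, with a range estimated from 40% to 65%, the width reflecting that only one example of the change is known and that it comes from a different core.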

Compound 4, a percentage reported as inhibition, in the whole organism at one dose (the size of the read-out at that dose, not a potency): 73.7%
Beside the measured number, compound 4's estimate is 20.7 percentage points below it, outside the stated range (above it).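

In this assay, the change from 4-chlorophenyl to 4-hydroxyphenyl on the core of compound 3 gave a number 5.3 percentage points higher from compound 3 to compound 4 (within the scatter) and so left no readable effect on this core, unlike the clear loss seen on the core of compound 1. The size of this step therefore does not carry from one core to the other, and a step measured on one core was a poor guide to the other in this series: the same change on two cores in this assay, a number 15.8 percentage points lower (beyond the scatter) from compound 1 to compound 2 and a number 5.3 percentage points higher (within the scatter) from compound 3 to compound 4, 21.1 percentage points apart, beyond the scatter of two such steps. This shows that the core matters to what the change does, but it does not show which feature of the two cores is responsible, and with a single pair on each core and a read-out taken at one dose, it gives no general rule for other cores or for potency.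

The compounds shown carry only chloro or hydroxy at this place on the aromatic ring, so it remains open what a methoxy group, an amine or a carboxylic acid would do there on either core. From the compounds shown here alone, it also remains open whether the change on a third core would resemble the step on the core of compound 1, the step on the core of compound 3, or neither.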